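A few compounds are considered here, and "the series" means these few. Any claim that something is new, unique, unknown or untested is made for them only; others in the source may bear on it.

Measured compounds in a functional assay on DU-145 cells (Homo sapiens) for cytotoxicity, in the presence of a further agent that is not named here; on this read-out lower numbers stand for stronger inhibition and higher numbers for weaker inhibition:

compound 1, `Clc1ccc(-c2cc(-c3ccsc3)nc(-c3ccccc3Cl)c2)o1`, gives 19300 nM
compound 2, `Clc1ccc(-c2cc(-c3cccs3)nc(-c3ccccc3Cl)c2)o1`, gives 16800 nM
compound 3, `Cc1ccc(-c2cc(-c3ccc(Cl)o3)cc(-c3cccs3)n2)cc1`, gives 19300 nM

The three compounds share one core and differ only in the groups hung on it. Compound 1 differs from compound 2 by thiophen-3-yl in place of thiophen-2-yl on an aromatic carbon, and that exchange made a step of a 1.1-fold higher number from compound 2 to compound 1 (0.06 log units; within the scatter). Compound 3 differs from compound 2 by 4-methylphenyl in place of 2-chlorophenyl on an aromatic carbon, which made a step of a 1.1-fold higher number from compound 2 to compound 3 (0.06 log units; within the scatter). Compound 3 and compound 1 therefore stand at the same number in this assay, and none of the three is separated from the others by more than the usual scatter.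

Compound 4, `Cc1ccc(-c2cc(-c3ccc(Cl)o3)cc(-c3ccsc3)n2)cc1`, has not yet been measured. It differs from compound 3 by thiophen-3-yl in place of thiophen-2-yl on an aromatic carbon. Within the data shown here, this is the same kind of change as the one from compound 2 to compound 1, though the surroundings are not identical: in compound 2 the place is meta to a 2-chlorophenyl group, while in compound 3 it is meta to a 4-methylphenyl group. Since the earlier exchange gave only a 1.1-fold higher number from compound 2 to compound 1 (0.06 log units; within the scatter), the step from compound 3 to compound 4 is also expected to be small, a 1.0-fold higher number from compound 3 to compound 4 (0.02 log units; within the scatter), resting on that one measured pair alone. Compound 4 is accordingly expected to give about 20000 nM in this assay, with a likely range from 10000 nM to 40000 nM.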

Compound 4, half-maximal inhibitory concentration: 21200 nM
Estimate against measurement, compound 4: 1.1-fold (0.03 log units) below, and the stated range covers the measured number.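

In this assay, thiophen-3-yl in place of thiophen-2-yl on the core carrying 4-methylphenyl gave a 1.1-fold higher number from compound 3 to compound 4 (0.04 log units; within the scatter), and 4-methylphenyl in place of 2-chlorophenyl on the core carrying thiophen-3-yl gave a 1.1-fold higher number from compound 1 to compound 4 (0.04 log units; within the scatter). The thiophene exchange behaved alike on both cores, so in these compounds its size carried from one to the other: the same change on two cores in this assay, a 1.1-fold higher number (0.06 log units; within the scatter) from compound 2 to compound 1 and a 1.1-fold higher number (0.04 log units; within the scatter) from compound 3 to compound 4, 1.0-fold (0.02 log units) apart, within the scatter of two such steps The aryl exchange also carried across, but every step here lies within the scatter, so the agreement shows only that neither change separated the compounds on these two cores, and it does not show that either change would stay this small on another core: the same change on two cores in this assay, a 1.1-fold higher number (0.06 log units; within the scatter) from compound 2 to compound 3 and a 1.1-fold higher number (0.04 log units; within the scatter) from compound 1 to compound 4, 1.0-fold (0.02 log units) apart, within the scatter of two such steps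

All four compounds carry a 5-chlorofuran-2-yl group and two aromatic groups free of any charged or strongly hydrogen-bonding substituent, so the compounds shown leave open whether an amine or a carboxylic acid on the aryl group would shift the number at all. They also leave open whether a longer chain in place of the chlorine on the furan, or a saturated ring in place of the thiophene, would separate compounds in a way that these closely matched exchanges could not.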